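This account rests on a few compounds, and the source may have more. Where it says the series, first, only, none or still open, it means among the compounds named here.

Compound 1 `COC(C)(C)[C@@H](O)C(=O)N1N=CC[C@H]1C(=O)NCc1cc(Cl)ccc1-n1cnnn1` is measured in an ADME assay on Caco-2 cells (Homo sapiens) for permeability, read by LC-MS, in the apical to basolateral direction, with a stated time of 60 min, at pH 6.5 (a higher number here means that the compound crosses the layer faster, a lower number that the compound crosses the layer more slowly), and gives 1.7 10^-6 cm/s, the lower of the two numbers in hand. Compound 2 `CC(C)(C)C[C@@H](O)C(=O)N1CC[C@@H]2C[C@@]21C(=O)NCc1cc(Cl)ccc1-n1cnnn1` gives 7.8 10^-6 cm/s in this assay, a higher figure, though the two structures differ in more than one place. Compound 3 `CC(C)CC[C@@H](O)C(=O)N1N=CC[C@H]1C(=O)NCc1cc(Cl)ccc1-n1cnnn1` differs from compound 1 in a single place: isopentyl in place of 1-methoxy-1-methylethyl on a saturated chain carbon bound to a carbonyl carbon and an oxygen on a saturated carbon. For the measured compounds named here, no comparable step is available among the measured compounds. The change for compound 3 is expected to give a moderate rise, a 2.1-fold higher number from compound 1 to compound 3 (0.31 log units; beyond the scatter), and not a shift beyond that. Compound 3 is estimated at 3.5 10^-6 cm/s, within a range from 1.6 10^-6 cm/s to 8 10^-6 cm/s.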

Compound 3, apparent permeability: 29 10^-6 cm/s
For compound 3 the middle estimate is 8.3-fold (0.92 log units) below the measured one, and the stated range ends below it.
By their numbers in this assay, from the lowest: compound 1; then compound 2; then compound 3.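

At the saturated chain carbon bound to a carbonyl carbon and an oxygen on a saturated carbon, isopentyl in place of 1-methoxy-1-methylethyl produces a large step in this assay (a 17-fold higher number from compound 1 to compound 3 (1.23 log units; beyond the scatter)). The swap keeps the heavy-atom count and removes the hydrogen-bond acceptor of the leaving group. No measurement in hand explains the size of this step.

For the compounds shown here, whether the ether oxygen alone accounts for the step remains open, since only this pair differs in one place. As far as these compounds go, how a longer chain or an amine would behave here also remains open.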